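An Isopropyl Removed: Expectation for Compound 4

The source may report more compounds than this note shows. Statements on the series, on what has been measured and on what is new or still open speak of the compounds shown alone.

Compound 1 `CC(C)c1ccc(Oc2ccc(O)c(O)c2)c(-c2ccsc2S(=O)(=O)NCCNC(=S)Nc2cc(C(F)(F)F)cc(C(F)(F)F)c2)c1` gives 3700 nM in a functional assay on RS4-11 cells (Homo sapiens) for inhibition, read by CCK-8 assay, with a stated time of 48 h; on this read-out higher numbers stand for weaker inhibition and lower numbers for stronger inhibition.
Compound 2 `O=C(NCCNS(=O)(=O)c1ccc(-c2ccccc2O[C@H]2CC[C@@H](O)CC2)s1)Nc1ccc([N+](=O)[O-])cc1` gives 12400 nM in this assay.
Compound 3 `COc1ccc(Oc2cc(C)ccc2-c2ccsc2S(=O)(=O)NCCNC(=O)Nc2cc(C(F)(F)F)cc(C(F)(F)F)c2)cc1OC` gives 5600 nM in this assay.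

Going by the values given here, compound 1 stands at the lowest of the three numbers measured so far. Its nearest neighbour is compound 3, whose number is higher by an amount that lies within the scatter, so the two cannot be placed in order. Compound 2 sits further away, and that gap lies beyond the scatter, so compound 2 shows the weaker inhibition of the pair.

Compound 4 `O=S(=O)(NCCNC(=S)Nc1cc(C(F)(F)F)cc(C(F)(F)F)c1)c1sccc1-c1ccccc1Oc1ccc(O)c(O)c1` has not yet been measured. It is derived from compound 1 by one change: hydrogen in place of isopropyl on an aromatic carbon. Among the compounds with values here, no step between two measured compounds matches this change, so there is nothing to read its size from directly.

On this footing, the step of a 1.4-fold higher number from compound 1 to compound 4 (0.13 log units; within the scatter) is estimated to be small, leaning toward a somewhat higher number but not clearly beyond the scatter. Compound 4 is therefore expected to give about 5000 nM in this assay, with a plausible range from 2000 nM to 14000 nM.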

Compound 4, half-maximal inhibitory concentration: 4800 nM
Beside the measured number, compound 4's estimate is 1.0-fold (0.02 log units) above it; the measured number falls inside the stated range.
By their numbers in this assay, from the lowest: compounds 1, 4 and 3 (each within the scatter of the next); then compound 2.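

Going by these compounds alone, the exchange of isopropyl for hydrogen on the aromatic carbon para to the 3,4-dihydroxyphenoxy group is the first step in this set between compounds that differ in one place, and in this assay it reads as a 1.3-fold higher number from compound 1 to compound 4 (0.11 log units; within the scatter), so compound 1 and compound 4 cannot be placed in order. The earlier compounds shown here could say nothing about this position on its own, whereas this pair shows that, as far as this read-out can tell, hydrogen serves there as well as isopropyl, with its 3 heavy atoms. No measurement offered here bears on this result.

From the compounds shown here alone, what an amine, a carboxylic acid or a longer alkyl chain on this same carbon would do to the number remains open, since isopropyl and hydrogen mark only two points at this position and neither tells how far the position can be pushed. The step is also seen only once, with the 3,4-dihydroxyphenoxy group in place, so whether it keeps its size with a methoxy-bearing phenoxy group there is unsettled.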